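Carbamate tail exchange on a weakly cytotoxic carbamate

A few compounds are considered here, and "the series" means these few. Any claim that something is new, unique, unknown or untested is made for them only; others in the source may bear on it.

Measured so far in a functional assay on PC-3 cells (Homo sapiens) for cytotoxicity, read by MTT assay, with a stated time of 72 h, tested at 10 uM; a lower number here means a stronger effect, a higher number a weaker effect of the compound at the concentration tested:
compound 1, `O=C(Nc1nc2cc(C(=O)c3ccccc3)ccc2[nH]1)OC1COC1`: 65.6%
compound 2, `COC(=O)Nc1nc2cc(C(=O)c3ccccc3N(C)C3COC3)ccc2[nH]1`: 54.8%
compound 3, `CCCSc1ccc2[nH]c(NC(=O)OCC3(C)COC3)nc2c1`: 79.3%

Compound 3 has the highest number of the three; its gap to compound 1 and its gap to compound 2 both lie beyond the scatter, so compound 3 shows the weakest effect of the set at this concentration. Compound 4, `CCCSc1ccc2[nH]c(NC(=O)OCCCN(C)C)nc2c1`, differs from compound 3 in one place: 2-(dimethylamino)ethyl in place of 3-methyloxetan-3-yl on a saturated chain carbon bound to an oxygen next to a carbonyl group. Among the compounds with values here, no step between measured compounds carries this change, so the expectation rests on compound 3 alone. The step of a number 7.3 percentage points lower from compound 3 to compound 4 (within the scatter) is expected to stay within the scatter, with no clear direction. Compound 4 is therefore estimated at 72%, with a range from 52% to 92%.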

Compound 4, a percentage reported as activity, at one concentration (the size of the read-out at that concentration, not a potency): 78.3%
The estimate for compound 4 lay 6.3 percentage points below the measured number; the measured number falls inside the stated range.
By their numbers in this assay, from the lowest: compound 2; then compound 1; then compounds 4 and 3 (each within the scatter of the next).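

In this assay, 2-(dimethylamino)ethyl in place of 3-methyloxetan-3-yl on a saturated chain carbon bound to an oxygen next to a carbonyl group gives a step of a number 1 percentage points lower from compound 3 to compound 4 (within the scatter), so the ring and the open chain with its tertiary amine cannot be told apart at this concentration. This single step shows that a change of ring to chain at this position, with the heavy-atom count unchanged, need not shift the read-out. Nothing measured accounts for this result.

As far as these compounds go, whether a carboxylic acid or a longer chain at this place would move the number stays open. So does whether the same exchange behaves alike on the core of compound 1.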